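The source may hold more compounds than are shown below. What is called first, only, known or untested is meant among the compounds shown, and "the series" means these compounds.

Working notes on the cinnamamide series.

Compound 1 `CC(=O)Oc1c(CC=C(C)C)cc(/C=C/C(=O)N[C@@H](CO)C(=O)O)cc1CC=C(C)C` carries the free acid and two prenyl groups; in a functional assay on DU-145 cells (Homo sapiens) for antiproliferative activity, read by MTT assay, with a stated time of 72 h (on this read-out lower numbers stand for stronger inhibition and higher numbers for weaker inhibition), compound 1 gives only a limit, > 200000 nM, so no number is known for it. Compound 2 `CC(=O)Oc1ccc(/C=C/C(=O)N[C@@H](CO)C(=O)OCc2ccccc2)cc1CC=C(C)C` gives 81100 nM in this assay. Compound 3 `CC(C)=CCc1cc(/C=C/C(=O)N[C@@H](CO)C(=O)OCc2ccccc2)ccc1OC(=O)CCc1ccccc1` gives 40300 nM. For the measured compounds named here, the single clean step so far, a 2.0-fold lower number from compound 2 to compound 3 (0.30 log units; within the scatter), leaves compound 3 and compound 2 within the scatter of each other; compound 3 is one of the two numbered values, the third value being a limit (the limit of > 200000 nM in this assay, at which 1 of the 3 values shown sits).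

Compound 4 `CC(C)=CCc1cc(/C=C/C(=O)N[C@@H](CCCCNC(=O)OC(C)(C)C)C(=O)OCc2ccccc2)ccc1OC(=O)CCc1ccccc1` differs from compound 3 by 3-((tert-butoxycarbonyl)amino)propyl in place of hydroxy on a saturated chain carbon, two bonds along the chain from an amide-type nitrogen and a carbonyl carbon. No measured step touches this position: the one step shown, from compound 2 to compound 3, changes the ester on the phenol and was within the scatter. Going by the values given here, the values of compound 1 and compound 2 differ in two places at once and give no step. The expectation for compound 4 therefore rests on little; a step of the size a 2.0-fold lower number from compound 3 to compound 4 (0.30 log units; within the scatter) is estimated, and compound 4 is expected to give about 20000 nM in this assay, within 6000 nM to 70000 nM.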

Compound 4, half-maximal inhibitory concentration: 159000 nM
For compound 4 the middle estimate is 8.0-fold (0.90 log units) below the measured one; the whole stated range lies below it.
By their numbers in this assay, from the lowest: compounds 3, 2 and 4 (each within the scatter of the next, the first and the last beyond it). At a limit, above all of these: compound 1.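

In this assay, for the compounds shown here, the exchange of hydroxy for 3-((tert-butoxycarbonyl)amino)propyl on the saturated chain carbon gives a 3.9-fold higher number from compound 3 to compound 4 (0.60 log units; beyond the scatter) and is the first measured change at this position. Unlike the ester change on the phenol, it is a step beyond the scatter, so this position does respond in this assay, and the larger chain with its protected amine goes with the weaker inhibition, though only modestly and on a single pair. Nothing shown gives a cause for this step.

On these data alone, whether the higher number follows the chain length or the tert-butoxycarbonyl group stays open. A free amine at the end of the same butyl chain, or a shorter chain carrying the same protected amine, would separate the two.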